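Carbamate Inhibitors of a Flavin Amine Oxidase: One Benzyl Step

This account rests on a few compounds, and the source may have more. Where it says the series, first, only, none or still open, it means among the compounds named here.

In an assay on BTI-TN-5B1-4 cells for inhibition of Amine oxidase [flavin-containing] B (Homo sapiens), read by fluorescence and Amplex Red, using microsomes, with a stated time of 15 min (a lower number here means a stronger inhibitor, a higher number a weaker inhibitor), three compounds have been measured so far.
Compound 1 `C#CCN1CCC(OC(=O)Nc2ccccc2)CC1` gives > 100000 nM, a limit of the assay rather than a number.
Compound 2 `O=C(Nc1ccccc1)OC1CCN(Cc2ccccc2)CC1` gives > 100000 nM, likewise a limit of the assay.
Compound 3 `C#CCN1CCC(COC(=O)Nc2ccc(C(C)C)cc2)CC1` gives 316 nM.

Compound 2 thus stands at the limit shared by two of the three values, (the limit of > 100000 nM in this assay, at which 2 of the 3 values shown sit); no number is known for it, only that it is at best a weak inhibitor. Among the measured compounds shown here, the single step between compounds differing in one place, a step that the two limits leave unreadable from compound 1 to compound 2, runs from one limit to another and cannot be read in size. Compound 4 `CC(C)c1ccc(NC(=O)OC2CCN(Cc3ccccc3)CC2)cc1` differs from compound 2 in one place: isopropyl in place of hydrogen on an aromatic carbon. For the measured compounds named here, no measured step bears directly on this change. Compound 3 carries the same isopropyl group together with a different chain on the ring nitrogen and an additional chain carbon in its link to the carbamate, and it reaches a measurable value, whereas compound 1 sits at the limit; those two compounds differ in two places at once, so the share of the isopropyl group cannot be separated out. Compound 4 is therefore expected to move off the limit, with an estimated step of an at least 20-fold lower number from compound 2 to compound 4 (1.30 log units; beyond the scatter). Compound 4 is estimated at 5000 nM, within 500 nM to 100000 nM, with a fair chance that only a limit is reported again.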

Compound 4, half-maximal inhibitory concentration: > 100000 nM
Compound 4 was reported as a limit; the forecaster's own chance of this, stated with the estimate: 35%; middle value at least 20-fold (1.30 log units) away from the limit.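

Compound 2 and compound 4 both sit at a limit of the assay rather than at a number, so no step between them can be read: the limit of > 100000 nM in this assay, at which 3 of the 4 values shown sit.

The compounds shown leave open which structural feature goes with the measurable result of compound 3 at 316 nM, and whether the isopropyl group contributes at all.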